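The compounds below may be only part of what the source reports. "The series", "measured", "known", "first", "only" and "open" are said of these compounds alone.

Measured compounds:
compound 1 `COc1ccc(NC(=O)c2cccc(/C=C3\CC(=O)N(c4ccccc4)C3=O)c2)cc1` — > 100000 nM, a limit of the assay
compound 2 `CCCCCN1C(=O)C/C(=C\c2cccc(C(=O)Nc3cccc(F)c3)c2)C1=O` — > 100000 nM, a limit of the assay
compound 3 `COc1ccc(NC(=O)c2cccc(/C=C3\CC(=O)N(c4ccc(C)cc4)C3=O)c2)cc1` — 93000 nM

In an ADME assay on SW480 cells (Homo sapiens) for cytotoxicity, read by MTT assay, with a stated time of 72 h (a higher number here means a weaker inhibitor, a lower number a stronger inhibitor), compound 1 returns > 100000 nM, which is a limit of the assay and not a number. Compound 2 likewise sits at a limit, > 100000 nM. For the measured compounds named here, compound 3 is the one measured compound with a number, 93000 nM. Only compound 1 and compound 3 differ in a single place: an at least 1.0-fold lower number from compound 1 to compound 3 (0.03 log units; that floor lies within the scatter). Going by the values given here, that step stays within the scatter, and it is the only measured step in the set.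

Compound 4 `CCc1cccc(NC(=O)c2cccc(/C=C3\CC(=O)N(c4ccccc4)C3=O)c2)c1` differs from compound 1 in another place: 3-ethylphenyl in place of 4-methoxyphenyl on an amide-type nitrogen. Among the compounds with values here, no measured step covers this change, so no size or direction beyond the scatter can be drawn from the data; the only guide is the limit of > 100000 nM in this assay, at which 2 of the 3 values shown sit. Compound 4 is therefore expected to give 100000 nM, with a range from 50000 nM to 200000 nM, and quite possibly again only as a limit. The estimated step is a number no higher from compound 1 to compound 4 (the limit leaves the size open), none beyond the scatter.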

Compound 4, half-maximal inhibitory concentration: 88600 nM
The estimate for compound 4 lay 1.1-fold (0.05 log units) above the measured number; measured number inside the range.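

Replacing 4-methoxyphenyl with 3-ethylphenyl on the amide-type nitrogen gives, in this assay, an at least 1.1-fold lower number from compound 1 to compound 4 (0.05 log units; that floor lies within the scatter). For the compounds shown here, this is the first change at this place that ends in a number rather than a limit, and it shows that an entering group with no hydrogen-bond acceptor, where the leaving group had one, still gives no step printed as beyond the scatter. Since compound 1 holds only a limit, the true size of the step stays unknown, and the values shown still crowd at the top of the assay's range: the limit of > 100000 nM in this assay, at which 2 of the 4 values shown sit.

The compounds shown leave open whether an amine or a carboxylic acid on this phenyl group would move the number beyond the scatter. They also leave open what a longer chain in place of the ethyl group would do.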